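The compounds below may be only part of what the source reports. "The series", "measured", "known", "first", "only" and "open" are said of these compounds alone.

Series notes. The shared core of compound 1 `N=c1c(C(N)=O)cc(Cl)cn1Cc1ccccc1` carries a benzyl group on the aromatic nitrogen. Going by the values given here, in an assay on CHO-K1 cells for displacement of a labelled ligand from Alpha-1D adrenergic receptor (Homo sapiens), read by scintillation counting, with a stated time of 60 min (a lower number here means a stronger inhibitor, a higher number a weaker inhibitor), compound 1 gives 30 nM, the lowest of the two numbers so far. Compound 2 `N=c1c(C(N)=O)cc(Cl)cn1Cc1ccccn1` replaces the phenyl with a pyridin-2-yl and gives 420 nM; the step of a 14-fold higher number from compound 1 to compound 2 (1.15 log units; beyond the scatter) is large. Compound 3 `CS(=O)(=O)c1cccc(Cn2cc(Cl)cc(C(N)=O)c2=N)c1` keeps the phenyl and adds a substituent, (methylsulfonyl in place of hydrogen on an aromatic carbon), on an aromatic carbon of the six-membered carbon-only ring, meta to a large group. Among the compounds with values here, no measured step covers a substituent on that ring; the step from compound 1 to compound 2 alters the ring itself and bears on this only by showing that changes in this region can move the number strongly. A step of modest size toward a higher number, or none beyond the scatter, is therefore expected for compound 3, a 2.7-fold higher number from compound 1 to compound 3 (0.43 log units; beyond the scatter). Compound 3 is estimated at 80 nM, within a range of 25 nM to 300 nM.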

Compound 3, inhibition constant: 52 nM
Compound 3: middle estimate off by 1.5-fold (0.19 log units), on the high side; measured number inside the range.
By their numbers in this assay, from the lowest: compounds 1 and 3 (each within the scatter of the next); then compound 2.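

In this assay, methylsulfonyl in place of hydrogen on an aromatic carbon gives a 1.7-fold higher number from compound 1 to compound 3 (0.24 log units; within the scatter), so this substituent, meta to a large group on the six-membered aromatic ring of carbon only, leaves compound 3 not separable from compound 1. The earlier step, a 14-fold higher number from compound 1 to compound 2 (1.15 log units; beyond the scatter), showed that altering the ring itself can move the number strongly; a substituent on the intact ring, at this place, need not do so. The data hold no measurement that accounts for this result.

On these data alone, only methylsulfonyl has been seen on this ring, so whether an amine or a carboxylic acid on the same aromatic carbon would also stay within the scatter of compound 1 remains open. Also open, as far as these compounds go, is whether methylsulfonyl on the pyridin-2-yl ring of compound 2 would behave as it does on the phenyl ring.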